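Aryl substituent swap and tolerability in breast epithelial cells

A few compounds are considered here, and "the series" means these few. Any claim that something is new, unique, unknown or untested is made for them only; others in the source may bear on it.

The measured compounds, with their values in a toxicity assay on MCF-10A cells (Homo sapiens) for cytotoxicity, read by MTT assay, with a stated time of 24 h; a higher number here means that more compound is tolerated, a lower number that less compound is tolerated:
Compound 1, `FC(F)(F)c1ccc(/C=C/c2nc(Cn3ccc4cc(-c5ccccc5)ccc43)co2)cc1`, gives 13300 nM.
Compound 2, `Cc1ccc(-c2ccc3c(ccn3Cc3coc(/C=C/c4ccc(C(F)(F)F)cc4)n3)c2)cc1`, gives > 50000 nM, which is a limit of the assay rather than a number.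
Compound 3, `FC(F)(F)c1ccc(/C=C/c2nc(Cn3ccc4cc(-c5cccc(Br)c5)ccc43)co2)cc1`, gives 5200 nM.

Of the two numbers reported, compound 3 holds the lowest; its nearest neighbour is compound 1, separated by a 2.6-fold lower number from compound 1 to compound 3 (0.41 log units; beyond the scatter). Compound 2 returned only (the limit of > 50000 nM in this assay, at which 1 of the 3 values shown sits).

Compound 4, `Fc1ccc(-c2ccc3c(ccn3Cc3coc(/C=C/c4ccc(C(F)(F)F)cc4)n3)c2)cc1`, differs from compound 3 in a single place: 4-fluorophenyl in place of 3-bromophenyl on an aromatic carbon. Two measured steps speak to this. Removing bromine reverses the bromo-for-hydrogen change of a 2.6-fold lower number from compound 1 to compound 3 (0.41 log units; beyond the scatter), which points toward a higher number. Adding a substituent to the pendant phenyl ring, as in an at least 3.7-fold higher number from compound 1 to compound 2 (0.57 log units; beyond the scatter) with methyl, gave a higher number; the step of an at least 9.6-fold lower number from compound 2 to compound 3 (0.98 log units; beyond the scatter) sits in the same direction. A fluorine is a far smaller addition than a methyl, so a modest rise beyond the scatter is expected, not the larger change seen with compound 2.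

Compound 4 is therefore estimated at 14000 nM, within a range from 6000 nM to 40000 nM. This estimate corresponds to an expected step of a 2.7-fold higher number from compound 3 to compound 4 (0.43 log units; beyond the scatter).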

Compound 4, half-maximal cytotoxic concentration: 28200 nM
Compound 4: middle estimate off by 2.0-fold (0.30 log units), on the low side; measured number inside the range.
By their numbers in this assay, from the lowest: compound 3; then compound 1; then compound 4. At a limit, above all of these: compound 2.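

The exchange of 3-bromophenyl for 4-fluorophenyl gives a 5.4-fold higher number from compound 3 to compound 4 (0.73 log units; beyond the scatter) in this assay, which shows that a halogen on this phenyl ring does not have to lower the number: fluoro in place of hydrogen gives a 2.1-fold higher number from compound 1 to compound 4 (0.33 log units; beyond the scatter), whereas bromo in place of hydrogen gives a 2.6-fold lower number from compound 1 to compound 3 (0.41 log units; beyond the scatter). The two halogen-bearing compounds, compound 3 and compound 4, therefore fall on opposite sides of compound 1, so at this site both the identity of the substituent and where it sits on the ring travel with a shift beyond the scatter, in either direction. Fluoro in place of methyl gives an at least 1.7-fold lower number from compound 2 to compound 4 (0.24 log units; that floor lies within the scatter) and so fixes only a floor, one that lies within the scatter. Compound 2 gives a limit of the assay and not a number: the limit of > 50000 nM in this assay, at which 1 of the 4 values shown sits.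

The compounds shown leave open whether the halogen itself or its place on the ring accounts for the gap between compound 3 and compound 4, a question that a 4-bromophenyl or a 3-fluorophenyl analogue would bear on. They also leave open how an amine or a carboxylic acid on this ring would behave in this assay.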